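This account rests on a few compounds, and the source may have more. Where it says the series, first, only, none or still open, it means among the compounds named here.

The measured compounds:

Compound 1 `COc1cc(Cl)cc(-c2nn(-c3cccc(NC(=O)Nc4cccc(C(F)(F)F)c4)c3)cc2-c2ccncc2)c1` gives in a functional assay on HOP-62 cells (Homo sapiens) for inhibition, read by sulforhodamine B assay, with a stated time of 48 h, tested at 0.01 uM (on this read-out lower numbers stand for a stronger effect and higher numbers for a weaker effect at the one concentration tested), a value of 96%.
Compound 2 `COc1cc(Cl)cc(-c2nn(-c3cccc(NC(=O)Nc4ccc(Cl)c(C(F)(F)F)c4)c3)cc2-c2ccncc2)c1` gives in this assay a value of 100%.
Compound 3 `COc1cc(Cl)cc(-c2nn(-c3cccc(NC(=O)c4cccc(C(F)(F)F)c4)c3)cc2-c2ccncc2)c1` gives in this assay a value of 104%.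

Compound 2 stands second highest of the three numbers; its nearest neighbour is compound 1, with a number 4 percentage points higher from compound 1 to compound 2 (within the scatter), and compound 3 lies on its other side, with a number 4 percentage points higher from compound 2 to compound 3 (within the scatter). Going by the values given here, all three numbers sit within the usual scatter of one another, so none of the measured compounds can be set apart from the others at this concentration.

The next compound, compound 4 `O=C(Nc1cccc(-n2cc(-c3ccncc3)c(-c3cc(O)cc(Cl)c3)n2)c1)Nc1ccc(Cl)c(C(F)(F)F)c1`, differs from compound 2 in one place: hydrogen in place of methyl on an oxygen on an aromatic ring. Among the compounds with values here, none of the measured steps touches this part of the molecule; the changes that were measured, a number 4 percentage points higher from compound 1 to compound 2 (within the scatter), a number 8 percentage points higher from compound 1 to compound 3 (within the scatter) and a number 4 percentage points higher from compound 2 to compound 3 (within the scatter), all concern the other end of the molecule and all stayed within the scatter. The data therefore give no ground to expect a step beyond the scatter in this assay for compound 4 in either direction; the expected step is a number 1 percentage points lower from compound 2 to compound 4 (within the scatter). Compound 4 is estimated to give 99%, with a range from 87% to 110%.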

Compound 4, a percentage reported as activity, at one concentration (the size of the read-out at that concentration, not a potency): 99%
Estimate against measurement, compound 4: no gap at the digits printed; the range from low to high includes it.
By their numbers in this assay, from the lowest: compounds 1, 4, 2 and 3 (each within the scatter of the next).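

Among the compounds shown, compound 4 alone differs at this oxygen, and in this assay the change from methoxy to hydroxy gives a number 1 percentage points lower from compound 2 to compound 4 (within the scatter). Going by these compounds alone, the 3-chloro-5-methoxyphenyl end of the molecule, untouched by the earlier steps, therefore joins the other end in showing no step beyond the scatter at the one concentration tested. Nothing available alongside these numbers speaks to the cause of this result.

Since all the numbers lie so close together, the compounds shown leave open whether this position can influence the read-out at all under these conditions. On these data alone, it also remains open whether an ethoxy group or a longer chain on this oxygen, or an amine in its place, would give a step beyond the scatter in this assay.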